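Three macrocycles untouched at the cytotoxicity limit, a fourth awaited

A few compounds are considered here, and "the series" means these few. Any claim that something is new, unique, unknown or untested is made for them only; others in the source may bear on it.

The measured compounds, each giving only a limit in an ADME assay on Huh-7 cells (Homo sapiens) for cytotoxicity; a higher number here means that more compound is tolerated, a lower number that less compound is tolerated:
Compound 1 `CCC[C@H](NC(=O)[C@@H]1C[C@@H]2CN1C(=O)[C@H](C(C)(C)C)NC(=O)OCCCCCCc1cccc3c1CN(C3)C(=O)O2)C(=O)C(=O)CC1CC1` gives the limit > 50000 nM.
Compound 2 `CCC[C@H](NC(=O)[C@@H]1C[C@@H]2CN1C(=O)[C@H](C(C)(C)C)NC(=O)OCCCCCCc1cccc3c1CN(C3)C(=O)O2)C(=O)C(=O)NC1CCCC1` gives the limit > 50000 nM.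
Compound 3 `CCC[C@H](NC(=O)[C@@H]1C[C@@H]2CN1C(=O)[C@H](C(C)(C)C)NC(=O)OCCCCCCc1cccc3c1CN(C3)C(=O)O2)C(=O)C(=O)NCc1ccccc1` gives the limit > 50000 nM.

Compound 1 therefore stands at a limit of this assay, not at a number, and the two other values shown are limits as well. Compound 4 `CCC[C@H](NC(=O)[C@@H]1C[C@@H]2CN1C(=O)[C@H](C(C)(C)C)NC(=O)OCCCCCCc1cccc3c1CN(C3)C(=O)O2)C(=O)C(=O)NC(C)c1ccccc1` differs from compound 1 in one place: (1-phenylethyl)amino in place of cyclopropylmethyl on a carbonyl carbon. Two measured steps start from the same compound and change the same position. The step that the two limits leave unreadable from compound 1 to compound 2 and the step that the two limits leave unreadable from compound 1 to compound 3 both stay unreadable because of the limit of > 50000 nM in this assay, at which 3 of the 3 values shown sit. The step that the two limits leave unreadable from compound 2 to compound 3 is unreadable for the same reason. Within the data shown here, no measured step therefore gives a size or a direction for swapping the cyclopropylmethyl group for a (1-phenylethyl)amino group. The expectation for compound 4 is that this assay again reports a limit rather than a number, so the step that the limit leaves unreadable from compound 1 to compound 4 is estimated to be nothing beyond the scatter. In this assay compound 4 is estimated at 80000 nM, with a range from 30000 nM to 300000 nM.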

Compound 4, half-maximal cytotoxic concentration: > 50000 nM
Compound 4: a limit, no number; the forecaster's own chance of this, stated with the estimate: 85%; the middle value does not contradict the limit.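

Compound 4 also gives only a limit, so its steps from compound 1, compound 2 and compound 3 cannot be read in this assay and the evidence is this: the limit of > 50000 nM in this assay, at which 4 of the 4 values shown sit. Still open, going by these compounds, is how much of each compound is actually tolerated, and whether exchanging these groups changes that.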